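Methoxy for methoxymethyl on the pendant aryl ring

The source may report more compounds than this note shows. Statements on the series, on what has been measured and on what is new or still open speak of the compounds shown alone.

Three compounds of the shared core are measured in a physicochemical assay for lipophilicity, read by HPLC, at pH 7.5; a lower number here means a more polar compound, a higher number a more lipophilic compound. Compound 2 `CC[C@@H](Nc1c(C#N)c(-c2ccc(-c3ccccc3COC)cc2)nc2cnccc12)C(N)=O` gives 2.6. Compound 1 `CC[C@H](Nc1c(C#N)c(-c2ccc(Br)cc2)nc2cnccc12)C(N)=O` gives 2.3, a number within the scatter of compound 2; compound 3 `CC(Nc1c(C#N)c(-c2ccc(Br)cc2)nc2cnccc12)C(N)=O` gives 2.1, a lower number beyond the scatter of compound 2. Going by the values given here, the only single-point step measured so far, a number 0.20 log units lower from compound 1 to compound 3 (within the scatter), removes one carbon elsewhere on the molecule and stays within the scatter. Compound 4 `CC[C@@H](Nc1c(C#N)c(-c2ccc(-c3ccccc3OC)cc2)nc2cnccc12)C(N)=O` differs from compound 2 by methoxy in place of methoxymethyl on an aromatic carbon, again one carbon fewer. By analogy with compound 1 and compound 3, the step of a number 0.20 log units lower from compound 2 to compound 4 (within the scatter) is expected to be small and downward, if anything. Compound 4 is therefore estimated at 2.4, within 2.1 to 2.7.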

Compound 4, distribution coefficient: 2.7
Compound 4: middle estimate off by 0.30 log units, on the low side; measured number inside the range.
By their numbers in this assay, from the lowest: compounds 3, 1, 2 and 4 (each within the scatter of the next, the first and the last beyond it).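

In this assay the change from 2-(methoxymethyl)phenyl to 2-methoxyphenyl gives a number 0.10 log units higher from compound 2 to compound 4 (within the scatter) at this position, on an aromatic carbon ortho to a large group. One carbon fewer here therefore leaves the read-out unresolved, as does the earlier step elsewhere on the molecule, a number 0.20 log units lower from compound 1 to compound 3 (within the scatter) with a one-carbon change in the 1-carbamoylpropyl group. No supporting data bear on this result.

As far as these compounds go, whether an amine, a carboxylic acid or a longer chain at this position would move the read-out beyond the scatter stays open. Methoxy and methoxymethyl are the only two groups compared here.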